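Adding bromo to the phenyl ring of compound 3

The source may report more compounds than this note shows. Statements on the series, on what has been measured and on what is new or still open speak of the compounds shown alone.

Compound 1 `O=C(NS(=O)(=O)c1ccc(F)cc1)c1cncc(Br)c1`: 980 nM
Compound 2 `O=C(NS(=O)(=O)c1ccccc1)c1cccnc1Cl`: 14000 nM
Compound 3 `Cc1ccc(C(=O)NS(=O)(=O)c2ccccc2)c(Cl)n1`: 13400 nM

In a functional assay on MCF7 cells (Homo sapiens) for antiproliferative activity, read by MTT assay, with a stated time of 48 h (on this read-out lower numbers stand for stronger inhibition and higher numbers for weaker inhibition), compound 3 gives 13400 nM, level with compound 2, and the measured step is a 1.0-fold lower number from compound 2 to compound 3 (0.02 log units; within the scatter). Both stand well above compound 1 at 980 nM. Compound 4 `Cc1ccc(C(=O)NS(=O)(=O)c2ccc(Br)cc2)c(Cl)n1` differs from compound 3 by bromo in place of hydrogen on an aromatic carbon, with bromo in place of hydrogen on an aromatic carbon, para to a large group. Among the compounds with values here, the single measured step concerns a methyl group, not this change, so it gives little guidance. Compound 1 at 980 nM differs from compound 3 in more than one place and offers only a weak hint towards a lower number. The expected change is a 2.2-fold lower number from compound 3 to compound 4 (0.35 log units; beyond the scatter). For compound 4 the estimated value is 6000 nM, within an expected range of 1800 nM to 16000 nM.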

Compound 4, half-maximal inhibitory concentration: 1970 nM
Compound 4: middle estimate off by 3.0-fold (0.48 log units), on the high side, and the stated range covers the measured number.
By their numbers in this assay, from the lowest: compounds 1 and 4 (each within the scatter of the next); then compounds 3 and 2 (each within the scatter of the next).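

In this assay, the change from phenyl to 4-bromophenyl gives a 6.8-fold lower number from compound 3 to compound 4 (0.83 log units; beyond the scatter), showing that this position, para to a large group, responds to a single added atom. Within the data shown here, the only earlier single change, a methyl on the other side of the molecule, gave a 1.0-fold lower number from compound 2 to compound 3 (0.02 log units; within the scatter) and so left the number unmoved. Nothing measured here explains the step from bromo.

As far as these compounds go, whether chloro, an amine or a carboxylic acid at this position would lower the number as bromo does remains open.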